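Hydroxy for acetamido at the limit

The source may hold more compounds than are shown below. What is called first, only, known or untested is meant among the compounds shown, and "the series" means these compounds.

In an ADME assay on HepG2 cells (Homo sapiens) for cytotoxicity, read by luminescence, with a stated time of 72 h (on this read-out higher numbers stand for an effect only at larger amounts of compound and lower numbers for an effect already at smaller amounts), compound 1 (`CCOC(=O)c1c(-c2cccc(C(F)(F)F)c2)[nH]c2cc(OC)ccc2c1=O`) gives > 21500 nM as a limit. Compound 2 (`CCOC(=O)c1c(-c2cccc(NC(C)=O)c2)[nH]c2cc(OC)ccc2c1=O`) gives > 21500 nM as a limit too. Both results are the limit of > 21500 nM in this assay, at which 2 of the 2 values shown sit, and so compound 2 has no readable number. For the measured compounds named here, the one measured step is a step that the two limits leave unreadable from compound 1 to compound 2 and it offers no size to carry forward. Compound 3 (`CCOC(=O)c1c(-c2cccc(O)c2)[nH]c2cc(OC)ccc2c1=O`) has hydroxy in place of acetamido on an aromatic carbon. No change beyond the scatter, in either direction, is expected, and the estimated move is a step that the limit leaves unreadable from compound 2 to compound 3 in this assay on this reasoning. For compound 3 the estimated value is 25000 nM with an expected range from 11000 nM to 50000 nM in all likelihood reported as another limit.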

Compound 3, half-maximal effective concentration: > 21500 nM
Compound 3 was reported as a limit (the forecaster's own chance of this, stated with the estimate: 85%); the middle value lies beyond the limit too.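

No step can be read among compound 1, compound 2 and compound 3 in this assay, because all three give the same limit: the limit of > 21500 nM in this assay, at which 3 of the 3 values shown sit. The compounds shown leave open whether the three differ at all in this read-out.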